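This account rests on a few compounds, and the source may have more. Where it says the series, first, only, none or still open, it means among the compounds named here.

Compound 2, with the structure `COc1ccc(Sc2nc3cc(N)cc(N)c3nc2-c2ccccc2)cc1`, is the starting point of this step. In a functional assay on SW-620 cells (Homo sapiens) for inhibition, read by sulforhodamine B assay, with a stated time of 48 h (on this read-out lower numbers stand for higher toxicity in this test and higher numbers for lower toxicity in this test), compound 2 gives < 100000 nM, and this is a limit of the assay rather than a measured number. Among the measured compounds shown here, its only measured neighbour is compound 1, `Nc1cc(N)c2nc(-c3ccccc3)c(NCc3ccc(F)cc3)nc2c1`, which differs from it by (4-methoxyphenyl)sulfanyl in place of (4-fluorobenzyl)amino on an aromatic carbon. In this assay compound 1 gives < 100000 nM, again a limit and not a number. The step that the two limits leave unreadable from compound 1 to compound 2 therefore cannot be read, since (the limit of < 100000 nM in this assay, at which 2 of the 2 values shown sit). Compound 3, `Nc1cc(N)c2nc(-c3ccccc3)c(Sc3ccc(Cl)c(Cl)c3)nc2c1`, carries 3,4-dichlorophenyl in place of 4-methoxyphenyl on a sulfur. For the measured compounds named here, no measured step touches a change of this kind, so no direction and no size can be expected for it beyond the scatter; all that the measured values allow is that compound 3, like compound 2, is expected to sit on the lethal side of the limit. On that basis, compound 3 is estimated to give 10000 nM, within a range from 1000 nM to 80000 nM, which would mean an expected step that the limit leaves unreadable from compound 2 to compound 3.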

Compound 3, concentration lethal to 50% of the cells: < 100000 nM
Compound 3 was reported as a limit; the forecaster's own chance of this, stated with the estimate: 35%; the middle value lies beyond the limit too.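

No step can be read between compound 1, compound 2 and compound 3, because all three stop at the same limit rather than at a measured number: the limit of < 100000 nM in this assay, at which 3 of the 3 values shown sit.

The compounds shown leave open how far apart they truly lie in this assay, and whether 3,4-dichlorophenyl in place of 4-methoxyphenyl on the sulfur changes the toxicity at all.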